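Methylsulfanyl for methylamino on the shared core

A few compounds are considered here, and "the series" means these few. Any claim that something is new, unique, unknown or untested is made for them only; others in the source may bear on it.

Compound 1 `CNc1ncnc2c1c(-c1ccsc1)cn2[C@@H]1O[C@H](CO)[C@@H](O)[C@H]1O` is the point of departure. In a functional assay on HCT-116 cells (Homo sapiens), read by MTT assay, with a stated time of 72 h (a lower number here means a stronger inhibitor, a higher number a weaker inhibitor), compound 1 gives > 20000 nM, a limit of the assay rather than a number. Compound 2 `CNc1ncnc2c1c(-c1cccs1)cn2[C@@H]1O[C@H](CO)[C@@H](O)[C@H]1O` carries thiophen-2-yl in place of thiophen-3-yl on an aromatic carbon; in this assay compound 2 gives > 20000 nM, again a limit. Compound 3 `CNc1ncnc2c1c(-c1cc3ccccc3o1)cn2[C@@H]1O[C@H](CO)[C@@H](O)[C@H]1O` carries 1-benzofuran-2-yl at the same position; in this assay compound 3 gives > 20000 nM, also a limit. The steps from compound 1 to compound 2 a step that the two limits leave unreadable from compound 1 to compound 2, from compound 1 to compound 3 a step that the two limits leave unreadable from compound 1 to compound 3 and from compound 2 to compound 3 a step that the two limits leave unreadable from compound 2 to compound 3 therefore cannot be sized, because the limit of > 20000 nM in this assay, at which 3 of the 3 values shown sit, holds every value shown.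

Compound 4 `CSc1ncnc2c1c(-c1ccsc1)cn2[C@@H]1O[C@H](CO)[C@@H](O)[C@H]1O` differs from compound 1 by methylsulfanyl in place of methylamino on an aromatic carbon. Among the compounds with values here, no measured step touches this position, and the three values give no direction for it. The expectation for compound 4 is therefore that it stays at the limit, with a step that the limit leaves unreadable from compound 1 to compound 4 reflecting no readable change from compound 1; compound 4 is estimated at 25000 nM, ranging from 5000 nM to 100000 nM.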

Compound 4, half-maximal inhibitory concentration: > 20000 nM
Compound 4 was reported as a limit (the forecaster's own chance of this, stated with the estimate: 85%); the middle value lies beyond the limit too.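

The step from compound 1 to compound 4 cannot be read, because both values are limits: the limit of > 20000 nM in this assay, at which 4 of the 4 values shown sit.

The compounds shown leave open whether methylsulfanyl and methylamino, or thiophen-3-yl, thiophen-2-yl and 1-benzofuran-2-yl, differ at all in this assay.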